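Replacing the cyclobutyl amide arm with a methyl alkynyl amide

The source may hold more compounds than are shown below. What is called first, only, known or untested is meant among the compounds shown, and "the series" means these compounds.

compound 1 `O=C(/C=C/c1ccc(NC(=O)Nc2ccc(Cl)c(C(F)(F)F)c2)cc1)NC1CCC1`: 4530 nM
compound 2 `CC(NC(=O)CCc1ccc(NC(=O)Nc2ccc(Cl)c(C(F)(F)F)c2)cc1)c1ccccc1`: > 50000 nM
compound 3 `CC(NC(=O)c1ccc(-c2ccc(NC(=O)Nc3cc(C(F)(F)F)ccc3Cl)cc2)cc1)c1ccccc1`: 17700 nM

In a functional assay on MX1 cells (Homo sapiens) for inhibition, read by MTT assay, with a stated time of 120 h (on this read-out higher numbers stand for weaker inhibition and lower numbers for stronger inhibition), compound 1 gives 4530 nM, the lowest of the two true numbers in this small set. Compound 3 stands nearest with 17700 nM, a higher number by a margin beyond the usual scatter. Compound 2 reaches only a limit of the assay, > 50000 nM.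

The next compound, compound 4 `CNC(=O)C#Cc1ccc(NC(=O)Nc2ccc(Cl)c(C(F)(F)F)c2)cc1`, has not yet been measured. In it, 2-(methylcarbamoyl)ethynyl stands in place of 2-(cyclobutylcarbamoyl)ethenyl on an aromatic carbon (2-(methylcarbamoyl)ethynyl in place of 2-(cyclobutylcarbamoyl)ethenyl on an aromatic carbon). Among the measured compounds shown here, no measured pair in the set isolates this change, so any forecast in this assay remains loose. A modest rise in the number is expected, since compound 1 at 4530 nM already holds the lowest true number. The expected size of the change is a 1.8-fold higher number from compound 1 to compound 4 (0.25 log units; within the scatter). The estimated value for compound 4 is 8000 nM, with an expected range from 2000 nM to 32000 nM.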

Compound 4, half-maximal inhibitory concentration: 26400 nM
The estimate for compound 4 lay 3.3-fold (0.52 log units) below the measured number; measured number inside the range.
By their numbers in this assay, from the lowest: compound 1; then compounds 3 and 4 (each within the scatter of the next). At a limit, above all of these: compound 2.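

Among the compounds shown here, this is the first step in the set that isolates a single place: on an aromatic carbon para to a large group, 2-(methylcarbamoyl)ethynyl in place of 2-(cyclobutylcarbamoyl)ethenyl gives a 5.8-fold higher number from compound 1 to compound 4 (0.77 log units; beyond the scatter) in this assay. The number thus responds to what stands at this place, even though the two groups have the same hydrogen-bond donor and acceptor counts, so those counts alone do not keep compound 4 level with compound 1. Nothing measured here explains the difference.

As far as these compounds go, the step removes the cyclobutyl ring and exchanges the double bond for a triple bond at once, so the share of each stays open. A 2-(methylcarbamoyl)ethenyl or 2-(cyclobutylcarbamoyl)ethynyl group at this place would separate the two changes.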